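The source may hold more compounds than are shown below. What is called first, only, known or untested is meant among the compounds shown, and "the series" means these compounds.

Compound 1 `COc1ccc(Nc2cc(C)oc(=O)c2)cc1`; compound 2 `COc1ccc(Nc2cc(C3CCCCC3)oc(=O)c2)cc1`; compound 3 `CCCCCc1cc(Nc2ccc(OC)cc2)cc(=O)o1`.

In a functional assay on KBVIN cells (Homo sapiens) for cytotoxicity, read by MTT assay, with a stated time of 72 h (a lower number here means that less compound is needed, a higher number that more compound is needed for the effect), compound 2 gives 4.39 uM and compound 3 gives 4.84 uM. For compound 1 the result in this assay is a limit rather than a number, > 30 uM (the limit of > 30 uM in this assay, at which 1 of the 3 values shown sits). For the measured compounds named here, of the two numbers known, compound 3 holds the higher, yet its step of a 1.1-fold higher number from compound 2 to compound 3 (0.04 log units; within the scatter) stays within the scatter, so the two cannot be ordered.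

Compound 4 `COc1ccc(Nc2cc(/C=C/c3ccccc3)oc(=O)c2)cc1` differs from compound 3 by 2-phenylethenyl in place of pentyl on an aromatic carbon. The measured steps that touch this position are an at least 6.8-fold lower number from compound 1 to compound 2 (0.83 log units; beyond the scatter) and an at least 6.1-fold lower number from compound 1 to compound 3 (0.79 log units; beyond the scatter), both large, while a 1.1-fold higher number from compound 2 to compound 3 (0.04 log units; within the scatter) shows that a pentyl and a cyclohexyl give much the same number. A 2-phenylethenyl is larger again, so the step of a 1.4-fold lower number from compound 3 to compound 4 (0.14 log units; within the scatter) is expected to stay within the scatter. Compound 4 is therefore estimated at 3.5 uM, with a range from 1.2 uM to 10 uM.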

Compound 4, concentration for half-maximal effect: 0.1 uM
Compound 4: middle estimate off by 35-fold (1.54 log units), on the high side; measured number below the stated range.
By their numbers in this assay, from the lowest: compound 4; then compounds 2 and 3 (each within the scatter of the next). At a limit, above all of these: compound 1.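

The 2-phenylethenyl breaks the plateau that pentyl and cyclohexyl had suggested on this aromatic carbon next to the ring oxygen: in this assay the change gives a 48-fold lower number from compound 3 to compound 4 (1.68 log units; beyond the scatter) and a 44-fold lower number from compound 2 to compound 4 (1.64 log units; beyond the scatter). The position therefore does more than separate methyl from larger carbon groups, since a group with an aromatic ring and a double bond outside it stands well apart from the two saturated ones. Against methyl the change gives an at least 300-fold lower number from compound 1 to compound 4 (2.47 log units; beyond the scatter), and this step rests on a limit rather than a number: the limit of > 30 uM in this assay, at which 1 of the 4 values shown sits.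

The compounds shown leave open whether the double bond or the aromatic ring of the 2-phenylethenyl carries the step, which a 2-phenylethyl or a directly attached phenyl would separate. They also leave open whether a hydroxyl or an amine on that phenyl ring would keep the number this low.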